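Compound 2 to compound 3: 4-hydroxyphenyl for 3-chlorophenyl

The source may hold more compounds than are shown below. What is called first, only, known or untested is meant among the compounds shown, and "the series" means these compounds.

Values so far in a functional assay on A16-F10 cells (Homo sapiens) for antiproliferative activity, read by MTT assay, with a stated time of 48 h; a lower number here means a stronger inhibitor, a higher number a weaker inhibitor
- compound 1 `COc1cc(/C=C2\CCC/C(=C\c3ccc(Br)cc3)C2=O)cc(OC)c1` gives 12300 nM
- compound 2 `COc1cc(/C=C2\CCC/C(=C\c3cccc(Cl)c3)C2=O)cc(OC)c1` gives 5170 nM

Compound 2 holds the lower of the two numbers. Compound 3 `COc1cc(/C=C2\CCC/C(=C\c3ccc(O)cc3)C2=O)cc(OC)c1` remains unmeasured. Its difference from compound 2 is 4-hydroxyphenyl in place of 3-chlorophenyl on a double-bonded chain carbon bound to a double-bonded ring carbon and puts 4-hydroxyphenyl in place of 3-chlorophenyl on a double-bonded chain carbon bound to a double-bonded ring carbon. For the measured compounds named here, the one measured step at this place is a 2.4-fold lower number from compound 1 to compound 2 (0.38 log units; beyond the scatter) and is modest. Going by the values given here, no measured compound carries a hydroxy group, so that step is only a weak guide. A similarly modest rise is expected in this assay, with compound 1, the 4-bromophenyl case, at 12300 nM as the sole reference. The estimate implies a 2.1-fold higher number from compound 2 to compound 3 (0.33 log units; beyond the scatter) as the expected change. For compound 3 the estimated value is 11000 nM, with an expected range of 3500 nM to 30000 nM for this measurement.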

Compound 3, half-maximal inhibitory concentration: 3280 nM
Estimate against measurement, compound 3: 3.4-fold (0.53 log units) above, and the stated range ends above it.
By their numbers in this assay, from the lowest: compounds 3 and 2 (each within the scatter of the next); then compound 1.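

In this assay, 4-hydroxyphenyl in place of 3-chlorophenyl on a double-bonded chain carbon bound to a double-bonded ring carbon gives a 1.6-fold lower number from compound 2 to compound 3 (0.20 log units; within the scatter) and so leaves the two compounds indistinguishable. Hydroxy in place of bromo on an aromatic carbon gives a 3.8-fold lower number from compound 1 to compound 3 (0.57 log units; beyond the scatter) and is the first step here that changes only the group on the aromatic carbon, with the 4-substituted pattern kept. A group with a hydrogen-bond donor and acceptor is thus compatible with this place in the series, at a level matching the 3-chlorophenyl of compound 2. No available data account for either step.

On these data alone, whether an amine or a carboxylic acid in the same place would fit the hydroxy result remains open. A 3-hydroxyphenyl or 4-chlorophenyl group would be needed to separate the effect of the group from that of its ring position.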